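A few compounds are considered here, and "the series" means these few. Any claim that something is new, unique, unknown or untested is made for them only; others in the source may bear on it.

Of the compounds shown here, three sharing one core have been measured in an assay on CHO cells for displacement of a labelled ligand from adenosine receptor A3 (Homo sapiens), read by scintillation counting, tested at 10 uM; a higher number here means more inhibition at the concentration tested (going by the name of the read-out), a lower number less inhibition. Compound 1 `CC(C)(C)Cc1c(-c2ccoc2)sc(N)c1C(=O)c1ccc(Cl)cc1` gives 1% in this assay. Compound 2 `CC(C)(C)Cc1c(-c2cccc(F)c2F)sc(N)c1C(=O)c1ccc(Cl)cc1` gives 1%, and compound 3 `CC(C)(C)Cc1c(-c2c(F)cccc2F)sc(N)c1C(=O)c1ccc(Cl)cc1` gives 1%. The three values sit level: the step of no change at the digits printed from compound 1 to compound 2 (within the scatter), the step of no change at the digits printed from compound 1 to compound 3 (within the scatter) and the step of no change at the digits printed from compound 2 to compound 3 (within the scatter) all stay within the scatter, so compound 3 stands with compounds 1 and 2 at the digits shown, none of them separated from another.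

Compound 4 `CC(C)(C)Cc1c(/C=C/c2ccc(Cl)cc2)sc(N)c1C(=O)c1ccc(Cl)cc1` is the next compound and has not been measured. Its structural change from compound 3 is 2-(4-chlorophenyl)ethenyl in place of 2,6-difluorophenyl on an aromatic carbon. The measured steps that bear on this are those in which the group on that same aromatic carbon was exchanged, from compound 1 to compound 2, from compound 1 to compound 3 and from compound 2 to compound 3; each of them was within the scatter. On that basis the step expected in this assay is a number 2 percentage points higher from compound 3 to compound 4 (within the scatter), that is, none beyond the scatter. Compound 4 is therefore estimated at 3% in this assay, with a range from 0% to 15%.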

Compound 4, a percentage reported as inhibition, at one concentration (the size of the read-out at that concentration, not a potency): 11%
Beside the measured number, compound 4's estimate is 8 percentage points below it; the measured number falls inside the stated range.
By their numbers in this assay, from the lowest: compounds 1, 2, 3 and 4 (each within the scatter of the next).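

In this assay, the 2-(4-chlorophenyl)ethenyl group on the aromatic carbon next to the ring sulfur gives three steps: a number 10 percentage points higher from compound 3 to compound 4 (within the scatter), a number 10 percentage points higher from compound 2 to compound 4 (within the scatter) and a number 10 percentage points higher from compound 1 to compound 4 (within the scatter). The earlier compounds shown here carried only a ring bonded straight to this carbon, whereas this group places a double bond outside aromatic rings between the carbon and its six-membered ring, and even this change leaves all four compounds unseparated. Nothing available accounts for the size of these steps.

Still open, as far as these compounds go, is whether any group at this position can move the inhibition beyond the scatter, such as an amine, a carboxylic acid or a longer chain ending in the 4-chlorophenyl ring. The compounds also leave open how the neopentyl, amino and (4-chlorophenyl)carbonyl groups bear on this read-out, since all three stay fixed throughout.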